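The source may report more compounds than this note shows. Statements on the series, on what has been measured and on what is new or still open speak of the compounds shown alone.

Of the compounds shown here, two have been tested in a functional assay (plasma) for inhibition, with Oryctolagus cuniculus as the target (on this read-out higher numbers stand for an effect only at larger amounts of compound and lower numbers for an effect already at smaller amounts), and neither gives a number. Compound 1 (`CCOC(=O)c1c(C)cc2cnn(-c3ccc(OC)c(OC)c3)c(=O)c2c1C`) reads >= 50 uM, which is only a limit of the assay. Compound 2 (`COc1cc2cnn(-c3ccccc3)c(=O)c2cc1OC`) reads >= 100 uM, and this too is only a limit. Compound 3 (`COc1cc2cnn(-c3ccccc3Cl)c(=O)c2cc1OC`) differs from compound 2 in one place: chloro in place of hydrogen on an aromatic carbon, so phenyl becomes 2-chlorophenyl. For the measured compounds named here, no measured step covers this change, so no shift beyond the scatter is expected in this assay. The estimated step is a number no higher from compound 2 to compound 3 (the limit leaves the size open). The value expected for compound 3 is 100 uM, estimated to lie between 40 uM and 250 uM.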

Compound 3, concentration for half-maximal effect: >= 100 uM
Compound 3 gave a limit, no number; the forecaster's own chance of this, stated with the estimate: 75%; the middle value sits exactly at the limit.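

For the compounds shown here, compound 2 and compound 3 each gave only a limit, not a number, so no step between them can be read. Going by these compounds, whether phenyl and 2-chlorophenyl differ in effect at all remains open.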